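Methoxy in Place of Trifluoromethyl on Two Different Rings

This account rests on a few compounds, and the source may have more. Where it says the series, first, only, none or still open, it means among the compounds named here.

Of the compounds shown here, three have been tested in a functional assay on KYSE-70 cells for antiproliferative activity against KYSE-70 cell line (Homo sapiens), read by MTT assay, with a stated time of 72 h; a lower number here means a stronger inhibitor, a higher number a weaker inhibitor. Compound 1 `COc1cccc(NC(=O)c2cc(=O)[nH]c3cc(Br)ccc23)c1` gives only a limit of the assay, > 20000 nM. Compound 2 `O=C(Nc1cccc(C(F)(F)F)c1)c1cc(=O)[nH]c2cc(Br)ccc12` likewise gives only a limit, > 20000 nM. Among the measured compounds shown here, compound 3 `O=C(Nc1cc(F)cc(F)c1)c1cc(=O)[nH]c2cc(C(F)(F)F)ccc12` is the single compound with a number, 14200 nM. The difference between the cores of compound 2 and compound 3 is not broken down here. Compound 1 differs from compound 2 by methoxy in place of trifluoromethyl on an aromatic carbon; the size of the step that the two limits leave unreadable from compound 2 to compound 1 cannot be read because the limit of > 20000 nM in this assay, at which 2 of the 3 values shown sit, caps both values.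

Compound 4 `COc1ccc2c(C(=O)Nc3cc(F)cc(F)c3)cc(=O)[nH]c2c1` is not yet measured and differs from compound 3 by methoxy in place of trifluoromethyl on an aromatic carbon. This is the same kind of change as from compound 2 to compound 1, but not the same: in compound 1 the methoxy sits on a six-membered aromatic ring meta to a large group, whereas in compound 4 it sits on a ring of a fused system, meta to a fused ring and para to a fused ring. For compound 4 a step of a 1.3-fold higher number from compound 3 to compound 4 (0.10 log units; within the scatter) is expected, resting on the unreadable measured step and on compound 3 at 14200 nM. Compound 4 is therefore estimated at 18000 nM, between 7000 nM and 45000 nM, with a real chance that only a limit is reported.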

Compound 4, half-maximal inhibitory concentration: > 20000 nM
Compound 4: only a limit was reported; the forecaster's own chance of this, stated with the estimate: 45%; middle value at least 1.1-fold (0.04 log units) away from the limit.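

In this assay compound 4 gives > 20000 nM, which is a limit of the assay and not a number. Methoxy in place of trifluoromethyl on the ring that is part of the fused system therefore gives an at least 1.4-fold higher number from compound 3 to compound 4 (0.14 log units; that floor lies within the scatter), so the change brings no stronger inhibitor here, but the true size of the step remains unknown and may be no more than ordinary scatter. The same change on the other ring, from compound 2 to compound 1, cannot be read, so this pair shows neither that the change carries over from one core to another nor that it fails to, because the values meet the same ceiling: the limit of > 20000 nM in this assay, at which 3 of the 4 values shown sit.

The compounds shown leave open whether any group on this carbon can give a clearly lower number than compound 3 at 14200 nM. Going by these compounds, how an amine, a carboxylic acid or a longer chain such as ethoxy would read at that place remains unknown.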